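The source may report more compounds than this note shows. Statements on the series, on what has been measured and on what is new or still open speak of the compounds shown alone.

Working notes on the series.

Of the compounds shown here, two have been measured in an ADME assay on HL-60 cells (Homo sapiens) for cytotoxicity, read by MTT assay, with a stated time of 3 days; a higher number here means that more compound is tolerated, a lower number that less compound is tolerated. Compound 1 `[N-]=[N+]=N[C@@H]1C[C@@H](n2ccc(NO)nc2=O)O[C@H]1CO` gives 2000000 nM in this assay. Compound 2 `Cc1cn([C@@H]2C[C@@H](O)[C@H](CO)O2)c(=O)nc1NO` gives 600000 nM in this assay, the lower of the two numbers; the gap between compound 2 and compound 1 lies beyond the usual scatter of the measurement. Among the compounds with values here, compound 1 and compound 2 differ in more than one place, so no single structural step connects the two measured values.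

Compound 3 `O=c1nc(NO)ccn1[C@@H]1C[C@@H](O)[C@H](CO)O1` is the next compound to be measured in this assay. It differs from compound 2 in one place: hydrogen in place of methyl on an aromatic carbon. Within the data shown here, no measured pair isolates this change, so nothing measured tells how the step should fall. Without such a reference, the expectation is that the step from compound 2 to compound 3 stays within the scatter, a 1.3-fold higher number from compound 2 to compound 3 (0.12 log units; within the scatter), with no direction preferred. On that basis compound 3 is estimated at 800000 nM in this assay, with an expected range from 300000 nM to 2500000 nM.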

Compound 3, half-maximal cytotoxic concentration: 460000 nM
Estimate against measurement, compound 3: 1.7-fold (0.24 log units) above; the measured number falls inside the stated range.
By their numbers in this assay, from the lowest: compounds 3 and 2 (each within the scatter of the next); then compound 1.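

In this assay, this series now has its first pair that isolates the aromatic carbon ortho to a hydroxyamino group: hydrogen in place of methyl there gives a 1.3-fold lower number from compound 2 to compound 3 (0.12 log units; within the scatter) and so leaves the number within the scatter. Within the data shown here, the same compound 3 also gives the first readable step on the saturated ring carbon, where hydroxy in place of azido gives a 4.3-fold lower number from compound 1 to compound 3 (0.64 log units; beyond the scatter), which lies beyond the scatter, so here less compound is tolerated with hydroxy than with azido on a core that carries hydrogen on the aromatic carbon. Nothing at hand accounts for either step, and no other measurement bears on them.

Going by these compounds, each of these two steps rests on a single pair, so it remains open whether hydroxy in place of azido would fall the same way on a core that carries methyl on the aromatic carbon. On these data alone, what an ethyl chain, chlorine or an amine would do on the aromatic carbon, or an amine or fluorine on the saturated ring carbon, also remains open.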